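Methylsulfanyl for Ethyl on the Shared Core

A few compounds are considered here, and "the series" means these few. Any claim that something is new, unique, unknown or untested is made for them only; others in the source may bear on it.

Of the compounds shown here, two built on the same core have been tested in an assay on HEK293 cells for positive allosteric modulation of metabotropic glutamate receptor 5 (Rattus norvegicus); a higher number here means that more compound is needed for the effect, a lower number that less compound is needed. Compound 1 `CNc1ncc(C#Cc2ccc(C)cc2)cn1` carries a methylamino group on the core, and in this assay compound 1 gives 704000 nM, a very weak result. Compound 2 `CCc1ncc(C#Cc2ccc(C)cc2)cn1` carries an ethyl group in that place, and in this assay compound 2 is reported as "not active" (no number reported), so no single number marks where it stands; it can only be said that it did not reach a measurable effect.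

Compound 3 `CSc1ncc(C#Cc2ccc(C)cc2)cn1` differs from compound 2 in one place: methylsulfanyl in place of ethyl on an aromatic carbon. Within the data shown here, no step between measured compounds is available to size this change, so any expectation for compound 3 in this assay rests on two weak or silent neighbors. At most a small gain relative to compound 2, if any, is expected, with a real chance of another result without a number. Compound 3 is estimated at 600000 nM in this assay, expected within 100000 nM to 3000000 nM.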

Compound 3, half-maximal effective concentration: "not active" (no number reported)
For compound 3 the study gives words and no number, and the estimate cannot be compared.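

Compound 2 and compound 3 are both reported as not active, without a number, in this assay, and no step can be read between them. The compounds shown leave open whether methylsulfanyl in place of ethyl changes the result at all on this shared core. Nothing measured here offers an explanation for this result.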